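The compounds below may be only part of what the source reports. "The series", "measured", "known", "first", "only" and "open" are said of these compounds alone.

Of the compounds shown here, three sharing a common core have been measured in a functional assay on T47D cells (Homo sapiens) for inhibition, read by sulforhodamine B assay, with a stated time of 48 h; on this read-out higher numbers stand for weaker inhibition of growth and lower numbers for stronger inhibition of growth. Compound 1 `COc1ccc(NC(=O)Nc2n[nH]c3ccccc23)cc1` gives 100000 nM. Compound 2 `CCCCOc1ccc(NC(=O)n2nc(N)c3ccccc32)cc1` gives 14800 nM. Compound 3 `Nc1nn(C(=O)Nc2c(F)cccc2F)c2ccccc12` gives 68700 nM. On these numbers compound 2 stands lowest, meaning the strongest inhibition of growth of the three: compound 3 is nearest, with a number higher by more than the usual scatter, and compound 1 is furthest, also beyond the scatter.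

The next compound, compound 4 `Nc1nn(C(=O)Nc2ccc(Cc3ccccc3)cc2)c2ccccc12`, has not yet been measured. It differs from compound 2 in one place: benzyl in place of butoxy on an aromatic carbon. The exchange sits on an aromatic carbon of a six-membered aromatic ring of carbon only, para to a large group. Among the measured compounds shown here, no measured pair shows this exact exchange, so the size of its effect cannot be read from the data. The expectation is a small step in this assay, if anything toward stronger inhibition of growth, and one that could well lie within the scatter of repeated measurements. Compound 4 is therefore estimated at 10000 nM, with a likely range from 3000 nM to 40000 nM. The step this estimate means, a 1.5-fold lower number from compound 2 to compound 4 (0.17 log units; within the scatter), is expected to be modest.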

Compound 4, concentration for 50% growth inhibition: 1550 nM
For compound 4 the middle estimate is 6.5-fold (0.81 log units) above the measured one; measured number outside the range, below it.
By their numbers in this assay, from the lowest: compound 4; then compound 2; then compounds 3 and 1 (each within the scatter of the next).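

In this assay, among the compounds shown here, placing benzyl instead of butoxy on this aromatic carbon, para to a large group, gives a 9.5-fold lower number from compound 2 to compound 4 (0.98 log units; beyond the scatter), the first change at a single place that can be read. The result shows that this position responds clearly to the group it carries, and that a group with a six-membered aromatic ring of carbon only can take the place of an open chain here while growth inhibition grows stronger, even though the one hydrogen-bond acceptor of butoxy is gone. Nothing measured here explains why the number falls, so the step stands as an observation only.

As far as these compounds go, this single pair changes several things at once, so it remains open whether the step follows the aromatic ring, the larger group or the missing oxygen; a phenoxy group or a plain pentyl chain on the same carbon would help to pull these apart. From the compounds shown here alone, it also remains open whether a substituted benzyl, such as one carrying a fluorine on its ring, would move the number further in either direction.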